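Hydroxy to methoxy on compound 2

The source may hold more compounds than are shown below. What is called first, only, known or untested is meant among the compounds shown, and "the series" means these compounds.

Within the data shown here, compound 2 (`Cc1cc(/C=C/c2ccc(O)c(O)c2)on1`) gives 7900 nM in a functional assay on S1 cells (Homo sapiens) for cytotoxicity, read by MTT assay, with a stated time of 72 h (on this read-out higher numbers stand for weaker inhibition and lower numbers for stronger inhibition), and holds the lowest of the three numbers so far, beyond the scatter from both others. Compound 1 (`Cc1cc(/C=C/c2ccc(O)cc2)[nH]n1`) stands at 32900 nM on the same read-out. Compound 3 (`COc1ccc(/C=C/c2cc(C)no2)cc1`) stands at 76400 nM and holds the highest number.

Compound 4 (`COc1cc(/C=C/c2cc(C)no2)ccc1O`) has not yet been measured. Its difference from compound 2 is small (methyl in place of hydrogen on an oxygen on an aromatic ring): methyl in place of hydrogen on an oxygen on an aromatic ring, which reads as hydroxy to methoxy.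

Among the measured compounds shown here, no two measured compounds differ in one place only, so the series offers no direct precedent for this change. For the measured compounds named here, the only guide is indirect. Compound 3 carries methoxy and no hydroxy and gives 76400 nM as the highest number of the three, whereas compound 4 still carries hydroxy. A position between compound 2 and compound 3 therefore seems the most likely outcome. The expected change is a 3.0-fold higher number from compound 2 to compound 4 (0.48 log units; beyond the scatter) in the direction of weaker inhibition, beyond the scatter but with wide uncertainty. Compound 4 is estimated at 24000 nM (expected range 9000 nM to 65000 nM).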

Compound 4, half-maximal inhibitory concentration: 50500 nM
Compound 4: the middle estimate sits 2.1-fold (0.32 log units) below what was measured; low and high end bracket the measured number.
By their numbers in this assay, from the lowest: compound 2; then compounds 1, 4 and 3 (each within the scatter of the next, the first and the last beyond it).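

In this assay, among these compounds, this is the first direct reading at this position. Among the compounds shown here, only one place changes: a 6.4-fold higher number from compound 2 to compound 4 (0.81 log units; beyond the scatter), with methyl in place of hydrogen on an oxygen on an aromatic ring. The step runs towards weaker inhibition and lies beyond the scatter, so this hydroxy cannot be capped as methoxy without a loss on this read-out, even though compound 4 still carries a hydroxy at its other oxygen. For the compounds shown here, the single step gives the direction and size of the change at this one place, while no accompanying measurement offers any account of it.

A single methyl leaves open whether any group on this oxygen gives a similar loss or whether the outcome depends on the group, and an ethyl, a longer chain or an acetyl group would test that. On these data alone, it is also open whether the oxygen itself matters, which an amine at the same place would address, and whether the same change gives a step of similar size on the core of compound 1.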